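The compounds below may be only part of what the source reports. "The series", "measured", "known", "first", "only" and "open" are said of these compounds alone.

Compound 1, `C#Cc1cncc(O[C@@H]2CCNC2)c1`, was tested in an assay on a protein complex for binding affinity to Neuronal acetylcholine receptor; alpha4/beta2 (Rattus norvegicus) (on this read-out lower numbers stand for stronger inhibition and higher numbers for weaker inhibition), where compound 1 gives 62 nM. Among the compounds with values here, the only other number so far comes from compound 2, `C#Cc1cc(O[C@@H]2CCNC2)cnc1Cl`, which in this assay gives 46 nM. Compound 1 thus stands highest of the two numbers shown, yet the single step measured, a 1.3-fold lower number from compound 1 to compound 2 (0.13 log units; within the scatter), is too small to count as a real difference between the two. Compound 3, `C=Cc1cncc(O[C@@H]2CCNC2)c1`, has not been measured yet. It differs from compound 1 in one place: vinyl in place of ethynyl on an aromatic carbon. Within the data shown here, that change is of a different kind from the one measured step, which put chloro in place of hydrogen on an aromatic carbon, so nothing measured speaks directly to it. Among the measured compounds shown here, with no guide beyond the fact that the leaving and entering groups are alike in what is counted, and that the one step on this core stayed within the scatter, the expected outcome for compound 3 in this assay is a modest step, a 1.5-fold higher number from compound 1 to compound 3 (0.16 log units; within the scatter), with a higher number somewhat more likely than a lower one. Compound 3 is therefore estimated at 90 nM, in a range from 30 nM to 300 nM.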

Compound 3, half-maximal inhibitory concentration: 883 nM
Compound 3: the middle estimate sits 9.8-fold (0.99 log units) below what was measured; measured number above the stated range.
By their numbers in this assay, from the lowest: compounds 2 and 1 (each within the scatter of the next); then compound 3.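

Vinyl in place of ethynyl, on the aromatic carbon two atoms from the ring nitrogen, gives a 14-fold higher number from compound 1 to compound 3 (1.15 log units; beyond the scatter) in this assay and so shows that the number can move well beyond the scatter through a change at this position. This step is also the first one here to go beyond the scatter, and it comes from a swap that leaves much of what is counted untouched: both groups have 2 carbon heavy atoms, no ring, no hydrogen-bond donors or acceptors and no net charge, while a triple bond outside the aromatic ring becomes a double bond. Within the data shown here, nothing measured here explains why this swap moves the number so far.

On these data alone, whether ethyl, a nitrile or a longer chain such as propynyl at this position would give a number nearer that of compound 1 or that of compound 3 stays open. Also open, as far as these compounds go, is whether chloro in place of hydrogen, the change behind a 1.3-fold lower number from compound 1 to compound 2 (0.13 log units; within the scatter), would stay as small with vinyl in place of ethynyl.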